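Chloro for fluoro: solubility notes on the series

The source may report more compounds than this note shows. Statements on the series, on what has been measured and on what is new or still open speak of the compounds shown alone.

Measured so far, in a physicochemical assay for solubility, at pH 6.8; a higher number here means a more soluble compound, a lower number a less soluble compound:
Compound 1, `O=[N+]([O-])c1cn2c(n1)OC[C@@H](NCc1ccc(OC(F)(F)F)c(Oc3ccccc3)c1)C2`, gives < 2 ug/mL, which is a limit of the assay and not a number.
Compound 2, `O=[N+]([O-])c1cn2c(n1)OC[C@@H](NCc1ccc(OC(F)(F)F)c(O)c1)C2`, gives 56 ug/mL.
Compound 3, `O=[N+]([O-])c1cn2c(n1)OC[C@@H](NCc1ccc(OC(F)(F)F)c(F)c1)C2`, gives 43 ug/mL.

Compound 3 holds the lowest of the two numbers, with compound 2 nearest, the gap being a 1.3-fold lower number from compound 2 to compound 3 (0.11 log units; within the scatter). Compound 4 is `O=[N+]([O-])c1cn2c(n1)OC[C@@H](NCc1ccc(OC(F)(F)F)c(Cl)c1)C2`; it differs from compound 3 by chloro in place of fluoro on an aromatic carbon. Among the compounds with values here, no measured step swaps one halogen for another. The large steps, an at least 28-fold higher number from compound 1 to compound 2 (1.44 log units; beyond the scatter) and an at least 21-fold higher number from compound 1 to compound 3 (1.33 log units; beyond the scatter), both start from the phenoxy compound and do not bear on a halogen swap; the small step of a 1.3-fold lower number from compound 2 to compound 3 (0.11 log units; within the scatter) touches the same carbon. The expected step is therefore a 1.4-fold lower number from compound 3 to compound 4 (0.16 log units; within the scatter), within the scatter. Compound 4 is estimated at 30 ug/mL, between 12 ug/mL and 70 ug/mL.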

Compound 4, solubility: 77 ug/mL
For compound 4 the middle estimate is 2.6-fold (0.41 log units) below the measured one; measured number above the stated range.
By their numbers in this assay, from the lowest: compounds 3, 2 and 4 (each within the scatter of the next). At a limit, below all of these: compound 1.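

In this assay the step of a 1.8-fold higher number from compound 3 to compound 4 (0.25 log units; within the scatter) and the step of a 1.4-fold higher number from compound 2 to compound 4 (0.14 log units; within the scatter) leave chloro, fluoro and hydroxy on this aromatic carbon, ortho to a trifluoromethoxy group, unresolved from one another. This is the only halogen swap shown, and it stays inside the scatter. The phenoxy group alone stands apart, and the step of an at least 38-fold higher number from compound 1 to compound 4 (1.58 log units; beyond the scatter) rests on a limit of the assay: the limit of < 2 ug/mL in this assay, at which 1 of the 4 values shown sits.

Open, from the compounds shown here alone, is whether an amine, a carboxylic acid or a methoxy group on this carbon would stay with those three. Also open, going by these compounds, is whether the same halogen swap reads alike on another carbon of this ring.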